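Phosphate to Fluorine on the Aryl Ring: Expected Potency

The source may hold more compounds than are shown below. What is called first, only, known or untested is meant among the compounds shown, and "the series" means these compounds.

Compound 1 `Cc1nc(-c2ccc(F)cc2)c(C(=O)N2CCN(c3cccc(Cl)c3)CC2)o1` is measured in a functional assay on HL-60 cells (Homo sapiens) for inhibition, read by MTT assay, with a stated time of 72 h (a lower number here means a stronger inhibitor, a higher number a weaker inhibitor), at 40.1 nM. Compound 2 `COc1cccc(N2CCN(C(=O)c3oc(C)nc3-c3cccc(F)c3)CC2)c1` is reported in this assay as "not active" (no number reported), with no number given. Compound 3 `Cc1nc(-c2cccc(OP(=O)(O)O)c2)c(C(=O)N2CCN(c3cccc(Cl)c3)CC2)o1` carries a group of 5 heavy atoms on its aryl ring, and its result in this assay is only a limit of the assay, > 1000 nM. Among the three values shown, compound 3 stands at the limit of > 1000 nM in this assay, at which 1 of the 3 values shown sits, so its true value is not pinned down beyond that boundary, and compound 2 likewise has no single number.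

Compound 4 `Cc1nc(-c2cccc(F)c2)c(C(=O)N2CCN(c3cccc(Cl)c3)CC2)o1` is not yet measured. It differs from compound 3 in one place: one fluorine atom in place of a group of 5 heavy atoms (4 oxygen, 1 phosphorus; no ring), on an aromatic carbon. No measured pair differing in a single place is available, so the size of the step must be judged from the compounds shown. Compound 1, which also bears a single fluorine on that aryl ring together with the same chlorophenyl piperazine, gives 40.1 nM, and this suggests that replacing the phosphate with fluorine moves compound 4 toward the range of compound 1, a change well beyond the usual scatter. The step from compound 3 to compound 4 is therefore expected to be a large gain in potency, an at least 16-fold lower number from compound 3 to compound 4 (1.22 log units; beyond the scatter). Compound 4 is estimated at 60 nM, in a range from 15 nM to 300 nM.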

Compound 4, half-maximal inhibitory concentration: 33.7 nM
Beside the measured number, compound 4's estimate is 1.8-fold (0.25 log units) above it, within the range that was stated.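

Among these compounds, with fluoro in place of the group of 5 heavy atoms on the aromatic carbon, this assay now gives a direct step that changes this one place, an at least 29-fold lower number from compound 3 to compound 4 (1.47 log units; beyond the scatter), where the earlier compounds allowed only an indirect comparison. That step has only a lower bound, since the result for compound 3 is a limit of the assay: the limit of > 1000 nM in this assay, at which 1 of the 4 values shown sits. The exchange of 4-fluorophenyl for 3-fluorophenyl gives a step that lies within the scatter, a 1.2-fold lower number from compound 1 to compound 4 (0.08 log units; within the scatter), so these two placements of the fluorine are not told apart in this pair.

Going by these compounds, what a hydroxyl, an amine or a carboxylic acid would give on that aromatic carbon remains open, so it cannot be said whether fluorine itself matters or whether other small groups would serve equally well. Compound 2 is reported as not active with no number, so its comparison with compound 4, which bears a chlorine in place of its methoxy group on the piperazine's aryl ring, cannot be read as a step.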